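A few compounds are considered here, and "the series" means these few. Any claim that something is new, unique, unknown or untested is made for them only; others in the source may bear on it.

In an ADME assay on HUVEC cells (Homo sapiens) for inhibition, read by MTT assay, with a stated time of 48 h (on this read-out higher numbers stand for weaker inhibition and lower numbers for stronger inhibition), compound 1 `COc1cc(/C=N/Nc2nc(-c3ccc(Br)cc3)cs2)cc(Br)c1OC` gives > 100000 nM, which is a limit of the assay and not a number. Compound 2 `COc1cc(/C=N/Nc2nc(-c3cccc(Br)c3)cs2)cc(Br)c1OC` likewise reaches only a limit in this assay, giving > 100000 nM. The change from compound 2 to compound 1, (4-bromophenyl in place of 3-bromophenyl on an aromatic carbon), thus makes a step that a step that the two limits leave unreadable from compound 2 to compound 1. Compound 3 `Fc1ccc(/C=N/Nc2nc(-c3cccc(Br)c3)cs2)cc1F` also gives a limit in this assay, namely > 100000 nM. The difference between the core of compound 3 and that of compound 2 is not broken down here. All three values rest at the limit of > 100000 nM in this assay, at which 3 of the 3 values shown sit. Compound 4 `Fc1ccc(/C=N/Nc2nc(-c3ccc(Br)cc3)cs2)cc1F` is not yet measured and differs from compound 3 by the same change, (4-bromophenyl in place of 3-bromophenyl on an aromatic carbon). A step that stays unreadable is expected from compound 3 to compound 4 in this assay because the same change from compound 2 to compound 1 gives a step that a step that the two limits leave unreadable from compound 2 to compound 1. The expected step is a step that the limit leaves unreadable from compound 3 to compound 4. Compound 4 is accordingly estimated at 200000 nM.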

Compound 4, half-maximal inhibitory concentration: > 100000 nM
Compound 4: only a limit was reported; the forecaster's own chance of this, stated with the estimate: 85%; the middle value lies beyond the limit too.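

Going by these compounds alone, compound 3 and compound 4 both give only a limit, so no step between them can be read: the limit of > 100000 nM in this assay, at which 4 of the 4 values shown sit. The compounds shown leave open whether 4-bromophenyl and 3-bromophenyl differ at all in this assay, and how strongly any of the four inhibits.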